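The compounds below may be only part of what the source reports. "The series", "measured", "known", "first", "only" and "open" are said of these compounds alone.

Measured so far in a functional assay on SW480 cells (Homo sapiens) for cytotoxicity, read by MTT assay, with a stated time of 24 h; on this read-out higher numbers stand for weaker inhibition and lower numbers for stronger inhibition:

- compound 1, `C=CC1=C(C(=O)NCc2ccc(Cl)cc2)C(c2ccc(OC)c(OC)c2)OC1`, gives > 100000 nM, a limit of the assay.
- compound 2, `C=CC1=C(C(=O)NCc2ccc(Cl)cc2)C(c2ccc(OC)cc2)OC1`, gives > 100000 nM, a limit of the assay.
- compound 3, `C=CC1=C(C(=O)NCCC)C(c2ccc(Cl)c(Cl)c2)OC1`, gives > 100000 nM, a limit of the assay.

Compound 2 stands at the limit with no number attached to it. The two further values shown are also limits, so nothing in the set orders compound 2 against the other two. Going by the values given here, the only step between measured compounds that differ in one place, a step that the two limits leave unreadable from compound 1 to compound 2, hydrogen in place of methoxy on an aromatic carbon, cannot be read because the limit of > 100000 nM in this assay, at which 3 of the 3 values shown sit, is where both of its ends sit, and it is the point at which every measured value rests.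

Compound 4, `C=CC1=C(C(=O)NCCC)C(c2ccc(OC)cc2)OC1`, differs from compound 2 by ethyl in place of 4-chlorophenyl on a saturated chain carbon bound to an amide-type nitrogen. Among the compounds with values here, no measured step bears directly on this change. Compound 3 carries the propyl that enters here and sits at the limit. Compound 2 carries the 4-methoxyphenyl that stays and sits at the limit as well. Within the data shown here, with no readable step in hand, no step of a definite size or direction can be expected; the expectation for compound 4 is that a step that the limit leaves unreadable from compound 2 to compound 4 is a step not distinguishable from none, most likely reported again as a limit. Compound 4 is estimated at 150000 nM, within 100000 nM to 1000000 nM.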

Compound 4, half-maximal inhibitory concentration: > 100000 nM
Compound 4 ended at the assay's limit (the forecaster's own chance of this, stated with the estimate: 85%); the middle value does not contradict the limit.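

No new step can be read between compound 2 and compound 4, as both rest at a limit rather than a number: the limit of > 100000 nM in this assay, at which 4 of the 4 values shown sit.

The compounds shown leave open how 4-chlorobenzyl and propyl compare, and whether any member of this series gives a value short of the limit in this assay.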